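The source may hold more compounds than are shown below. What is called first, only, known or untested is meant among the compounds shown, and "the series" means these compounds.

Compound 1 `CC[C@H](CCn1cncn1)c1ccc(F)cc1`, compound 2 `CC[C@H](CCn1cncn1)c1ccc(C)cc1` and compound 3 `CCCC[C@H](CCn1cncn1)c1ccc(F)cc1` share a core and differ only in two places. In an ADME assay on HEp-2 cells (Homo sapiens) for cytotoxicity, read by MTT assay, with a stated time of 3 days (on this read-out higher numbers stand for lower toxicity in this test and lower numbers for higher toxicity in this test), compound 1 gives 103 ug/mL. Compound 2 differs from compound 1 by methyl in place of fluoro on an aromatic carbon, and in this assay compound 2 gives 75.2 ug/mL, so that a 1.4-fold lower number from compound 1 to compound 2 (0.14 log units; within the scatter). Compound 3 differs from compound 1 by ethyl in place of hydrogen on a saturated chain carbon, three bonds along the chain from an aromatic carbon; in this assay compound 3 gives 38.5 ug/mL, which means that a 2.7-fold lower number from compound 1 to compound 3 (0.43 log units; beyond the scatter). The numbers of compound 2 and compound 3 lie within the scatter of each other, so no order can be read between them.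

Compound 4 `CCCC[C@H](CCn1cncn1)c1ccc(C)cc1` has not yet been measured. It differs from compound 3 by methyl in place of fluoro on an aromatic carbon, the same change that separates compound 2 from compound 1. Because that earlier change gave a 1.4-fold lower number from compound 1 to compound 2 (0.14 log units; within the scatter), the step is expected to be about as small here, so that a 1.3-fold lower number from compound 3 to compound 4 (0.11 log units; within the scatter) is the estimate. Compound 4 is therefore expected to give about 30 ug/mL in this assay.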

Compound 4, half-maximal cytotoxic concentration: 23.7 ug/mL
Compound 4: middle estimate off by 1.3-fold (0.10 log units), on the high side; measured number inside the range.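

In this assay, methyl in place of fluoro on an aromatic carbon gives a 1.6-fold lower number from compound 3 to compound 4 (0.21 log units; within the scatter), and this step agrees with the one seen on the other core: the same change on two cores in this assay, a 1.4-fold lower number (0.14 log units; within the scatter) from compound 1 to compound 2 and a 1.6-fold lower number (0.21 log units; within the scatter) from compound 3 to compound 4, 1.2-fold (0.07 log units) apart, within the scatter of two such steps. Ethyl in place of hydrogen on a saturated chain carbon gives a 3.2-fold lower number from compound 2 to compound 4 (0.50 log units; beyond the scatter), and it also carries over: the same change on two cores in this assay, a 2.7-fold lower number (0.43 log units; beyond the scatter) from compound 1 to compound 3 and a 3.2-fold lower number (0.50 log units; beyond the scatter) from compound 2 to compound 4, 1.2-fold (0.07 log units) apart, within the scatter of two such steps. Across these four compounds, each change therefore looks much the same whichever form of the other position is present, but the methyl step stays within the scatter on both cores, so only the ethyl step is a clear shift, and neither comparison explains why the numbers move or shows that the steps would hold on other cores.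

The compounds shown leave open whether a chloro or methoxy group on the aromatic carbon would follow the same pattern. They also leave open whether a longer chain at the saturated carbon would lower the number further or whether the trend would stop there.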